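The compounds below may be only part of what the source reports. "The series", "measured", "known", "first", "only" and "open" are said of these compounds alone.

Measured in a functional assay on KB cells (Homo sapiens) for cytotoxicity, read by MTT assay, with a stated time of 72 h; a higher number here means a weaker inhibitor, a lower number a stronger inhibitor:

- compound 1 `O=S(=O)(c1ccccc1)c1nc2ccccc2nc1Nc1ccc(F)cc1`: > 50000 nM, a limit of the assay
- compound 2 `Cc1ccc(S(=O)(=O)c2nc3ccccc3nc2Nc2ccc(F)cc2)cc1`: 8950 nM
- compound 3 `COc1cc(Nc2nc3ccccc3nc2S(=O)(=O)c2ccc(Br)cc2)cc(OC)c1`: "not determined" (no result reported)

Compound 3 has no place on this scale, since compound 3 is recorded only as "not determined" (no result reported). Compound 4 `O=S(=O)(c1ccc(Br)cc1)c1nc2ccccc2nc1Nc1ccc(F)cc1` differs from it by 4-fluorophenyl in place of 3,5-dimethoxyphenyl on a nitrogen on an aromatic ring. Among the measured compounds shown here, no measured step covers this change. For the measured compounds named here, the only measured step, an at least 5.5-fold lower number from compound 1 to compound 2 (0.74 log units; beyond the scatter), is methyl in place of hydrogen on an aromatic carbon, a different change. Also in view is the limit of > 50000 nM in this assay, at which 1 of the 3 values shown sits. No size or direction can therefore be expected for a step from compound 3 in this assay. Compound 4 shares its 4-fluorophenyl group with compound 1 and compound 2, and the only number among these is that of compound 2 at 8950 nM. For compound 4 the estimated value is 15000 nM, with an expected range from 4000 nM to 50000 nM.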

Compound 4, half-maximal inhibitory concentration: 2280 nM
Estimate against measurement, compound 4: 6.6-fold (0.82 log units) above; the measured number lies below the stated range.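

In this assay bromo in place of methyl on an aromatic carbon gives a 3.9-fold lower number from compound 2 to compound 4 (0.59 log units; beyond the scatter) and shows that this place still responds beyond the methyl group of compound 2. Bromo in place of hydrogen at that place gives an at least 21-fold lower number from compound 1 to compound 4 (1.34 log units; beyond the scatter) on the same core. Compound 1 gives > 50000 nM as a limit of the assay, not a number.

The compounds shown leave open whether an amine or a carboxylic acid at this place would go with a lower or a higher number. They also leave open whether bromo gives a similar number with 3,5-dimethoxyphenyl in place of 4-fluorophenyl on the nitrogen.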